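Shortening the Pyridyl Linker After Removing Its Double Bond

The source may report more compounds than this note shows. Statements on the series, on what has been measured and on what is new or still open speak of the compounds shown alone.

Measured so far:
compound 1 `O=C(CCc1cccnc1)NCCCCCc1cn(-c2ccccc2-c2ccccc2)nn1` — 112%
compound 2 `O=C(/C=C/c1cccnc1)NCCCCCc1cn(-c2ccccc2-c2ccccc2)nn1` — 49%

Within the data shown here, in a functional assay on SH-SY5Y cells (Homo sapiens) for cytotoxicity, read by MTT assay, with a stated time of 48 h, tested at 100 nM (a higher number here means a weaker effect of the compound at the concentration tested, a lower number a stronger effect), compound 2 gives 49%, the lowest of the two numbers known, with compound 1 the nearest at a higher value. Compound 3 `O=C(Cc1cccnc1)NCCCCCc1cn(-c2ccccc2-c2ccccc2)nn1` carries (pyridin-3-yl)methyl in place of 2-(pyridin-3-yl)ethenyl on a carbonyl carbon. Among the measured compounds shown here, the only step that bears on this change is a number 63 percentage points lower from compound 1 to compound 2 (beyond the scatter), where the double bond outside aromatic rings entered; here it leaves again and the chain is shorter still. Compound 3 is therefore expected to move back toward compound 1, a step of a number 51 percentage points higher from compound 2 to compound 3 (beyond the scatter). Compound 3 is estimated at 100%, between 70% and 125%.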

Compound 3, a percentage reported as activity, at one concentration (the size of the read-out at that concentration, not a potency): 106%
Beside the measured number, compound 3's estimate is 6 percentage points below it, and the stated range covers the measured number.
By their numbers in this assay, from the lowest: compound 2; then compounds 3 and 1 (each within the scatter of the next).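

In this assay, the saturated (pyridin-3-yl)methyl group on the carbonyl carbon reverses what the 2-(pyridin-3-yl)ethenyl group brought (a number 57 percentage points higher from compound 2 to compound 3 (beyond the scatter)), and it stands level with the longer saturated chain (a number 6 percentage points lower from compound 1 to compound 3 (within the scatter)). Among these three compounds, only compound 2, which carries the double bond outside aromatic rings, stands apart, while chain length makes no difference beyond the scatter between the two saturated compounds. No measurement at hand accounts for this. Left open is whether the double bond needs the pyridin-3-yl ring to act. A phenyl group there, a triple bond in the linker or a longer saturated chain would bear on this.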